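Extending the piperazine substituent of compound 2

This account rests on a few compounds, and the source may have more. Where it says the series, first, only, none or still open, it means among the compounds named here.

Within the data shown here, compound 2 `Cc1ccc(-c2nnc(-c3ccc(CN4CCN(C)CC4)c(C(F)(F)F)c3)o2)cc1Nc1nccc(-c2cccnc2)n1` gives 510 nM in a functional assay on K562 cells (Homo sapiens) for inhibition, read by MTT assay, with a stated time of 72 h (on this read-out lower numbers stand for stronger inhibition and higher numbers for weaker inhibition), the lowest of the two numbers so far; its only neighbour, compound 1 `Cc1ccc(-c2nnc(-c3ccc(CN4CCN(C)CC4)cc3)o2)cc1Nc1nccc(-c2cccnc2)n1`, gives 4900 nM, and the step of a 9.6-fold lower number from compound 1 to compound 2 (0.98 log units; beyond the scatter) is the sole comparison available. Compound 3 `Cc1ccc(-c2nnc(-c3ccc(CN4CCN(CCN=C=S)CC4)c(C(F)(F)F)c3)o2)cc1Nc1nccc(-c2cccnc2)n1` differs from compound 2 by a group of 4 heavy atoms (2 carbon, 1 nitrogen, 1 sulfur; no ring) in place of a hydrogen atom, on a saturated chain carbon bound to an amine nitrogen in a ring. Among the measured compounds shown here, no measured step touches this chain: the one step known concerns the trifluoromethyl on an aromatic carbon, far from the site changed here, so nothing in the numbers foretells a direction. On that basis no step beyond the scatter is expected, and the estimate for compound 3 is 500 nM, within 120 nM to 2000 nM, corresponding to an expected step of a 1.0-fold lower number from compound 2 to compound 3 (0.01 log units; within the scatter).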

Compound 3, half-maximal inhibitory concentration: 500 nM
Estimate against measurement, compound 3: no gap at the digits printed, and the stated range covers the measured number.
By their numbers in this assay, from the lowest: compounds 3 and 2 (each within the scatter of the next); then compound 1.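

In this assay, placing a group of 4 heavy atoms (2 carbon, 1 nitrogen, 1 sulfur; no ring) in place of a hydrogen atom, on a saturated chain carbon bound to an amine nitrogen in a ring, gives a 1.0-fold lower number from compound 2 to compound 3 (0.01 log units; within the scatter). Among these compounds, this is the first reading at this site, and it shows that this group can stand there with the number remaining within the scatter; the only earlier step, a 9.6-fold lower number from compound 1 to compound 2 (0.98 log units; beyond the scatter), concerned the trifluoromethyl on an aromatic carbon and said nothing about this site. No measurement shown accounts for this result.

A single group cannot show whether other groups at this carbon, such as an amine, a carboxylic acid or a longer chain, would give a similar number. The trifluoromethyl step also remains unread in the presence of this group.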